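The source may report more compounds than this note shows. Statements on the series, on what has been measured and on what is new or still open speak of the compounds shown alone.

Measured compounds:
compound 1, `CC(=O)c1cnc(N2CCC(c3coc4c(N5CCc6cc(S(C)(=O)=O)ccc65)ncnc34)CC2)nc1`; in a functional assay on cells for agonist activity at Glucose-dependent insulinotropic receptor (Homo sapiens), read by a luciferase reporter, with a stated time of 4 h (on this read-out lower numbers stand for an effect already at smaller amounts and higher numbers for an effect only at larger amounts of compound), compound 1 gives 78 nM.
compound 2, `CS(=O)(=O)c1ccc2c(c1)CCN2c1ncnc2c(C3CCN(c4ncc(O)cn4)CC3)coc12`; in this assay compound 2 gives 391 nM.

Among the compounds with values here, compound 2 stands at the higher of the two numbers in this assay; its only neighbour is compound 1, and the step between them is a 5.0-fold higher number from compound 1 to compound 2 (0.70 log units; beyond the scatter). Compound 3, `CS(=O)(=O)c1ccc2c(c1)CCN2c1ncnc2c(C3CCN(c4ncc(F)cn4)CC3)coc12`, is not yet measured in this assay. It differs from compound 2 by fluoro in place of hydroxy on an aromatic carbon. Within the data shown here, no measured step bears directly on this exchange: the single known step, a 5.0-fold higher number from compound 1 to compound 2 (0.70 log units; beyond the scatter), shows only that the group at this position moves the number in this assay over a modest span, and the fluoro has no counterpart among the measured compounds. What the exchange does here cannot be read from compound 1 or compound 2, so the direction rests on the loss of the hydroxy alone. The expected step is a 2.0-fold lower number from compound 2 to compound 3 (0.29 log units; within the scatter), a modest move towards a lower number with a broad band around it. Compound 3 is expected to give 200 nM in this assay, estimated to lie between 60 nM and 650 nM.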

Compound 3, half-maximal effective concentration: 201 nM
Compound 3: middle estimate off by 1.0-fold (0.00 log units), on the low side; low and high end bracket the measured number.
By their numbers in this assay, from the lowest: compound 1; then compounds 3 and 2 (each within the scatter of the next).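

In this assay, the 5-hydroxypyrimidin-2-yl to 5-fluoropyrimidin-2-yl exchange gives a 1.9-fold lower number from compound 2 to compound 3 (0.29 log units; within the scatter), so the read-out does not separate these two groups, even though the hydrogen-bond donor and acceptor counted on the hydroxy are absent from the fluoro. The acetyl of compound 1 now stands apart from two different groups at this position, with a 2.6-fold higher number from compound 1 to compound 3 (0.41 log units; beyond the scatter) alongside the earlier 5.0-fold higher number from compound 1 to compound 2 (0.70 log units; beyond the scatter), so the gap is no longer tied to the hydroxy alone. No supporting data on hand bear on what lies behind this order of the three groups.

Still open, going by these compounds, is whether the lower number of compound 1 goes with the carbonyl of the acetyl or with the group as a whole, which a methyl ester, a primary amide or a nitrile at this position would help to separate. Also open, on these data alone, is whether the match between hydroxy and fluoro extends to other small groups, such as chloro, methoxy or an amine.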